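Shortening the Hexyl Chain of Compound 3 to Propyl

This account rests on a few compounds, and the source may have more. Where it says the series, first, only, none or still open, it means among the compounds named here.

In a functional assay on A549 cells (Homo sapiens) for antiproliferative activity, read by MTT assay, with a stated time of 48 h (a lower number here means a stronger inhibitor of growth, a higher number a weaker inhibitor of growth), compound 1 `Cc1ccc(-c2cnc(N(Cc3ccccc3)Cc3ccc(C(=O)NO)cc3)s2)cc1` gives 4410 nM, compound 2 `Cc1ccc(-c2cnc(N(Cc3ccc(C(=O)NO)cc3)CC(C)C)s2)cc1` gives 20400 nM and compound 3 `CCCCCCN(Cc1ccc(C(=O)NO)cc1)c1ncc(-c2ccc(C)cc2)s1` gives 3710 nM. Compound 3 stands at the low end of these numbers, level with compound 1, as the measured step shows: a 1.2-fold lower number from compound 1 to compound 3 (0.08 log units; within the scatter). Compound 2 stands apart from both, with a 4.6-fold higher number from compound 1 to compound 2 (0.67 log units; beyond the scatter).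

Compound 4 `CCCN(Cc1ccc(C(=O)NO)cc1)c1ncc(-c2ccc(C)cc2)s1` has not yet been measured. It differs from compound 3 at the end of the hexyl chain, which is cut back to propyl: hydrogen in place of propyl on a saturated chain carbon, three bonds along the chain from a nitrogen on an aromatic ring. In words, this is hydrogen in place of propyl on a saturated chain carbon, three bonds along the chain from a nitrogen on an aromatic ring. Going by the values given here, no measured step makes this exact change. The closest guide is the replacement of isopropyl by pentyl on a saturated chain carbon bound to a nitrogen on an aromatic ring, which gave a 5.5-fold lower number from compound 2 to compound 3 (0.74 log units; beyond the scatter). Compound 4 loses chain length in the opposite sense, so a move to a higher number is expected, probably somewhat smaller than that one. The expected step is a 3.0-fold higher number from compound 3 to compound 4 (0.47 log units; beyond the scatter). Compound 4 is estimated at 11000 nM, with an expected range from 5000 nM to 24000 nM.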

Compound 4, concentration for 50% growth inhibition: 3310 nM
Compound 4: middle estimate off by 3.3-fold (0.52 log units), on the high side; the measured number lies below the stated range.
By their numbers in this assay, from the lowest: compounds 4, 3 and 1 (each within the scatter of the next); then compound 2.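

In this assay, cutting the hexyl chain back to propyl leaves the number in place, with a 1.1-fold lower number from compound 3 to compound 4 (0.05 log units; within the scatter), so in this pair the outer part of the chain is not needed to hold this level of growth inhibition. The propyl compound also sits level with the compound carrying a phenyl on this carbon, with a 1.3-fold lower number from compound 1 to compound 4 (0.12 log units; within the scatter), while the single methyl that separates it from compound 2 goes with a clear change, a 6.2-fold lower number from compound 2 to compound 4 (0.79 log units; beyond the scatter), so compound 2 is the one that goes against an otherwise flat set and, among these compounds, the methyl branch matters here more than chain length does. No measurement on hand accounts for either the flat response to chain length or the effect of the branch.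

The compounds shown leave open whether the flat response continues to an ethyl or methyl group on the nitrogen, or ends somewhere along that shortening. Going by these compounds alone, they also leave open how this position would respond to a chain ending in an amine or a carboxylic acid, and whether a methyl branch placed elsewhere on the chain would give the same change as the one in compound 2.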